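The source may report more compounds than this note shows. Statements on the series, on what has been measured and on what is new or still open speak of the compounds shown alone.

In a physicochemical assay for solubility, in phosphate buffer, measured as kinetic solubility, at pH 7.4, tested at 250 uM (a higher number here means a more soluble compound, a lower number a less soluble compound), compound 1 (`CCCCCCCCNc1ccc(C(=O)O)cc1S(=O)(=O)NC`) gives 53000 nM and compound 2 (`CNS(=O)(=O)c1cc(C(=O)O)ccc1NCCCCCCCC(F)(F)F`) gives 242000 nM as the higher of the two numbers. Compound 3 (`O=C(O)c1ccc(NCCCCCCCC(F)(F)F)c(S(=O)(=O)N2CCCCC2)c1`) differs from compound 2 in one place, with piperidin-1-yl in place of methylamino on a sulfonyl sulfur. Among the measured compounds shown here, the only measured step (a 4.6-fold higher number from compound 1 to compound 2 (0.66 log units; beyond the scatter)) sits on the chain and not at the sulfonyl sulfur, so it offers only a rough scale. A step of similar size toward a lower number is expected (a 3.5-fold lower number from compound 2 to compound 3 (0.54 log units; beyond the scatter)). In this assay compound 3 is estimated at 70000 nM with an expected range (20000 nM to 200000 nM).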

Compound 3, solubility: 13000 nM
Beside the measured number, compound 3's estimate is 5.4-fold (0.73 log units) above it; measured number outside the range, below it.
By their numbers in this assay, from the lowest: compound 3; then compound 1; then compound 2.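

At the sulfonyl sulfur, this assay responds strongly to a single change: piperidin-1-yl in place of methylamino gives a 19-fold lower number from compound 2 to compound 3 (1.27 log units; beyond the scatter). This is a larger step than the one on the chain (a 4.6-fold higher number from compound 1 to compound 2 (0.66 log units; beyond the scatter)), so the sulfonyl sulfur is at least as sensitive a place to change as the chain end. No measurement here explains the drop.

The change removes a hydrogen-bond donor and adds a ring in one move, so the two cannot be told apart. Dimethylamino, or a smaller ring such as pyrrolidin-1-yl, on the same sulfur would help to separate them.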